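A few compounds are considered here, and "the series" means these few. Any claim that something is new, unique, unknown or untested is made for them only; others in the source may bear on it.

Measured compounds:
Compound 1, `O=C(Cc1cccnc1)c1cc2cc(Cl)ccc2[nH]1`: in an assay on isolated protein for inhibition of Indoleamine 2,3-dioxygenase 1 (Homo sapiens), read by spectrophotometry (a lower number here means a stronger inhibitor, a higher number a weaker inhibitor), compound 1 gives 24600 nM.
Compound 2, `O=C(Cc1cccnc1)c1cc2cc(Br)ccc2[nH]1`: in this assay compound 2 gives 18000 nM.

Among the measured compounds shown here, compound 2 stands at the lowest of the two numbers so far, but its nearest neighbour is compound 1, and the step of a 1.4-fold lower number from compound 1 to compound 2 (0.14 log units; within the scatter) lies within the scatter, so the two cannot be placed in order. That step, bromo in place of chloro on an aromatic carbon, is the only one that bears on what comes next.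

Compound 3, `Cc1ccc2[nH]c(C(=O)Cc3cccnc3)cc2c1`, differs from compound 2 by methyl in place of bromo on an aromatic carbon. For the measured compounds named here, one small group is swapped for another of the same size on the same aromatic carbon, much as in the one step already seen. Since exchanging chloro for bromo in that position moved the number only within the scatter, no step beyond the scatter is expected here either, in either direction. Compound 3 is therefore estimated at 22000 nM in this assay, with a range from 8000 nM to 60000 nM, meaning an expected step of a 1.2-fold higher number from compound 2 to compound 3 (0.09 log units; within the scatter).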

Compound 3, half-maximal inhibitory concentration: 87000 nM
Estimate against measurement, compound 3: 4.0-fold (0.60 log units) below, and the stated range ends below it.
By their numbers in this assay, from the lowest: compounds 2 and 1 (each within the scatter of the next); then compound 3.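

This position is less indifferent than the first pair suggested. Chloro and bromo could not be told apart in this assay, yet putting methyl on the same aromatic carbon gives a 4.8-fold higher number from compound 2 to compound 3 (0.68 log units; beyond the scatter) and a 3.5-fold higher number from compound 1 to compound 3 (0.55 log units; beyond the scatter), both beyond the scatter, and a higher number here means a weaker inhibitor. The counts computed from the structures do not separate these groups, since each swap exchanges one heavy atom for one heavy atom with no hydrogen-bond donors or acceptors on either side, and nothing available explains why methyl stands apart from the two halogens.

Three compounds cannot show whether this change belongs to methyl alone or also appears with other groups on this carbon, such as methoxy, an amine or a nitrile. As far as these compounds go, it also remains open how the core with only hydrogen on this carbon compares with these compounds, and whether the same exchange of bromo for methyl would shift the number similarly on another carbon of the ring.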